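Adding a Second Methoxy Group to Compound 1

The source may hold more compounds than are shown below. What is called first, only, known or untested is meant among the compounds shown, and "the series" means these compounds.

Compound 1 `COc1ccc(-c2cc(/C=C/C(=O)c3ccc(N)cc3)[nH]n2)cc1` gives 2420 nM
Compound 2 `COc1cc(-c2cc(/C=C/C(=O)c3ccc(Cl)c(Cl)c3)[nH]n2)cc(OC)c1OC` gives 5950 nM

In a functional assay on PC-3 cells (Homo sapiens) for inhibition, read by sulforhodamine B assay, with a stated time of 48 h (on this read-out lower numbers stand for stronger inhibition of growth and higher numbers for weaker inhibition of growth), compound 1 stands at the lower of the two numbers shown, and the number of compound 2 lies above it by more than the usual scatter. Compound 3 `COc1ccc(-c2cc(/C=C/C(=O)c3ccc(N)cc3)[nH]n2)cc1OC` differs from compound 1 by methoxy in place of hydrogen on an aromatic carbon. Among the compounds with values here, no measured pair shows this single change on its own, so the step of a 1.2-fold higher number from compound 1 to compound 3 (0.09 log units; within the scatter) is expected to be small, most likely within the scatter, with a slight lean toward a higher number. Compound 3 is therefore estimated at about 3000 nM, expected to fall between 1200 nM and 7500 nM.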

Compound 3, concentration for 50% growth inhibition: 3710 nM
Beside the measured number, compound 3's estimate is 1.2-fold (0.09 log units) below it; the range from low to high includes it.
By their numbers in this assay, from the lowest: compounds 1, 3 and 2 (each within the scatter of the next, the first and the last beyond it).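

In this assay the swap of hydrogen for methoxy on an aromatic carbon, ortho to a methoxy group, gives a 1.5-fold higher number from compound 1 to compound 3 (0.19 log units; within the scatter) and so stays within what repeated measurements would scatter. This position therefore accepts a second methoxy group without a clear change in growth inhibition. No supporting data are available to explain this result.

From the compounds shown here alone, whether this position accepts other groups in the same way remains open, for example a hydroxyl, an amine or a longer chain such as ethoxy. A group of any of these kinds could give a clearer step.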